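Two Ureas Measured, a Third Awaits Its Number

The compounds below may be only part of what the source reports. "The series", "measured", "known", "first", "only" and "open" are said of these compounds alone.

Compound 2, `COc1cc(NC(=O)Nc2cc(Nc3ccc(C)c(C)c3)ncn2)cc(OC)c1`: 45.3%
Compound 1, `Cc1ccc(Nc2cc(NC(=O)Nc3c(Cl)cccc3Cl)ncn2)cc1F`: 40.7%

Of the compounds shown here, two have been measured so far in a functional assay on NCI-H226 cells (Homo sapiens) for inhibition, read by MTT assay, with a stated time of 48 h, tested at 10 uM; on this read-out higher numbers stand for more inhibition at the one concentration tested (going by the name of the read-out) and lower numbers for less inhibition. Compound 2 gives 45.3% in this assay, and compound 1 gives 40.7%; the two numbers sit within the usual scatter of one another, so neither can be placed ahead of the other. Within the data shown here, no single-point step between them is on hand, as the two differ in more than one place.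

Compound 3, `COc1cc(NC(=O)Nc2cc(Nc3cc(Br)ccc3OC)ncn2)cc(OC)c1`, is yet to be measured in this assay. It differs from compound 2 in one place: 5-bromo-2-methoxyphenyl in place of 3,4-dimethylphenyl on a nitrogen on an aromatic ring. Among the measured compounds shown here, with no step between the measured compounds to lean on, the change is expected to bring no shift beyond the scatter, and the estimated step is a number 3.3 percentage points lower from compound 2 to compound 3 (within the scatter). Compound 3 is therefore expected to give about 42% in this assay, within a range from 25% to 60%.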

Compound 3, a percentage reported as inhibition, at one concentration (the size of the read-out at that concentration, not a potency): 42.7%
Compound 3: middle estimate off by 0.7 percentage points, on the low side; the range from low to high includes it.
By their numbers in this assay, from the lowest: compounds 1, 3 and 2 (each within the scatter of the next).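

Among these compounds, the step from the 3,4-dimethylphenyl to the 5-bromo-2-methoxyphenyl group gives the first reading of a single change on a nitrogen on an aromatic ring: in this assay there is a number 2.6 percentage points lower from compound 2 to compound 3 (within the scatter) and the read-out stays within the scatter. The exchange removes two methyl groups and brings in a bromine and a methoxy group, with one hydrogen-bond acceptor where the leaving group has none, yet at this one concentration the two compounds cannot be told apart. Nothing on hand accounts for this result, so it stands as an observation without an explanation.

From the compounds shown here alone, with both groups changing together, the separate contributions of the bromine and the methoxy group remain open. Also open, going by these compounds, is whether a ring carrying a carboxylic acid or a morpholine at this place would move the read-out beyond the scatter.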